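This account rests on a few compounds, and the source may have more. Where it says the series, first, only, none or still open, it means among the compounds named here.

Working notes on the series.

Compound 2 `C=CC[C@H]1C[C@]2([C@@H](C)Cc3ccc(OC)cc3)OCOC2=CC1=O` stands at the strong end of the set: in a functional assay on NCI-H460 cells (Homo sapiens) for antiproliferative activity, with a stated time of 72 h (on this read-out higher numbers stand for weaker inhibition and lower numbers for stronger inhibition), compound 2 gives 90 nM, the lowest of the three numbers measured. Compound 1 `C=CC[C@H]1C[C@]2([C@@H](C)Cc3ccc(OC)c(OC)c3)OCOC2=CC1=O` carries an additional methoxy on the aromatic ring and in this assay compound 1 gives 260 nM; the step of a 2.9-fold lower number from compound 1 to compound 2 (0.46 log units; beyond the scatter) lies beyond the scatter. Compound 3 `C=CC[C@H]1C[C@]2(C(C)Cc3ccc(OCC)cc3)OCOC2=CC1=O`, the ethoxy analogue without a defined side-chain configuration, in this assay gives 280 nM, again clearly above the number for compound 2. Both departures from the methoxy pattern of compound 2 therefore gave higher numbers.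

Compound 4 `C=CC[C@H]1C[C@]2([C@@H](C)Cc3ccc(OC(F)(F)F)cc3)OCOC2=CC1=O` introduces (trifluoromethyl in place of methyl on an oxygen on an aromatic ring). Among the compounds with values here, no measured step covers a trifluoromethyl entering in this way, so the only bearing is indirect: the values of compound 1 and compound 3 show that each alteration of the aromatic substitution seen so far moved the number upward by a modest amount. For compound 4 a modest rise in this assay relative to compound 2 is therefore expected, with a wide band of uncertainty, the expected step being a 2.4-fold higher number from compound 2 to compound 4 (0.39 log units; beyond the scatter). The estimate for compound 4 in this assay is 220 nM, expected to fall between 70 nM and 700 nM.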

Compound 4, half-maximal inhibitory concentration: 3800 nM
For compound 4 the middle estimate is 17-fold (1.24 log units) below the measured one, outside the stated range (above it).
By their numbers in this assay, from the lowest: compound 2; then compounds 1 and 3 (each within the scatter of the next); then compound 4.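

The group on the oxygen on the aromatic ring proves far from indifferent in this assay: the step of a 42-fold higher number from compound 2 to compound 4 (1.63 log units; beyond the scatter) is large, while the other measured step on this ring, a 2.9-fold lower number from compound 1 to compound 2 (0.46 log units; beyond the scatter), is modest. The exchange puts four heavy atoms where there was one, with no ring, no net charge and no change in the counted hydrogen-bond donors or acceptors, so a change that leaves those counts untouched can still carry a large loss of inhibition at this place. No measurement at hand accounts for the size of this step.

With only methoxy and trifluoromethoxy compared directly at this place, the series does not separate a contribution of the fluorine atoms from that of the larger group as a whole. As far as these compounds go, how a difluoromethoxy group, a free hydroxyl or a dimethylamino group would read on the aromatic ring, with the rest of compound 2 unchanged, remains open.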